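Benzoyl for 2-hydroxyphenyl on the shared core

This account rests on a few compounds, and the source may have more. Where it says the series, first, only, none or still open, it means among the compounds named here.

Within the data shown here, in a functional assay on RAW264.7 cells (Mus musculus) for inhibition, read by Griess assay, with stated times of 3 h and 24 h (on this read-out higher numbers stand for weaker inhibition and lower numbers for stronger inhibition), compound 1 `C=C1CCC2[C@](C)(CO)[C@H](O)CC[C@@]2(C)[C@@H]1CCOc1ccccc1O` gives 47700 nM as the only actual number so far. Compound 2 `C=C1CCC2[C@](C)(CO)[C@H](O)CC[C@@]2(C)[C@@H]1CCOc1ccc2ccc(=O)oc2c1` is reported as > 50000 nM which is a limit of the assay. Compound 3 `C=C1CCC2[C@](C)(CO)[C@H](O)CC[C@@]2(C)[C@@H]1CCOc1ccc2oc(-c3ccccc3)cc(=O)c2c1` is reported as > 100000 nM which is also a limit. Among the measured compounds shown here, neither limit offers a number to set against compound 1, and no measured pair isolates a single change.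

Compound 4 `C=C1CCC2[C@](C)(CO)[C@H](O)CC[C@@]2(C)[C@@H]1CCOC(=O)c1ccccc1` carries benzoyl in place of 2-hydroxyphenyl on an oxygen on a saturated carbon and keeps the core of compound 1. With so little to go on, no shift beyond the scatter is expected in this assay and a weak result remains likely, with a reported limit quite possible. The expected size of a 1.2-fold lower number from compound 1 to compound 4 (0.08 log units; within the scatter) stays within the usual scatter. Compound 4 is estimated at 40000 nM with an expected range from 15000 nM to 100000 nM on this read-out.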

Compound 4, half-maximal inhibitory concentration: > 100000 nM
Compound 4 gave a limit, no number; the forecaster's own chance of this, stated with the estimate: 40%; at least 2.5-fold (0.39 log units) between middle value and limit.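

In this assay, among these compounds, the swap on an oxygen on a saturated carbon gives an at least 2.0-fold higher number from compound 1 to compound 4 (0.32 log units; beyond the scatter), the first step that isolates a change in one place. Compound 4 sits at a limit of the assay, not at a number, so the step fixes only a minimum size: the limit of > 100000 nM in this assay, at which 2 of the 4 values shown sit. Benzoyl has 0 hydrogen-bond donors where 2-hydroxyphenyl has 1, but a single step cannot tie the change in read-out to that count.

Still open, as far as these compounds go, is whether any group at this place gives a number clearly lower than that of compound 1, at 47700 nM. An amine or a carboxylic acid in place of benzoyl would show whether this place tolerates anything beyond the 2-hydroxyphenyl of compound 1.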